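Swapping methyl for chloro on the pendant phenyl ring

The source may report more compounds than this note shows. Statements on the series, on what has been measured and on what is new or still open speak of the compounds shown alone.

Compound 1 `Cc1ccc(-c2csc(NC(=O)COc3ccccc3C)n2)cc1` was tested in a functional assay on MDA-MB-468 cells (Homo sapiens) for cytotoxicity, read by MTT assay, with a stated time of 48 h (a higher number here means a weaker inhibitor, a lower number a stronger inhibitor), where compound 1 gives 52100 nM, the highest of the two numbers recorded. Its nearest neighbour is compound 2 `Cc1ccc(-c2csc(NC(=O)COc3ccc(F)cc3)n2)cc1`, which in this assay gives 24900 nM; the change of a 2.1-fold lower number from compound 1 to compound 2 (0.32 log units; beyond the scatter) put 4-fluorophenyl in place of 2-methylphenyl on the oxygen side of the shared core. Compound 3 `Cc1ccccc1OCC(=O)Nc1nc(-c2ccc(Cl)cc2)cs1` alters the other end instead: chloro in place of methyl on an aromatic carbon, para to a large group. Among the compounds with values here, no measured step touches that ring, so the only guide is how small the one known step was, and nothing says this exchange of one halogen for one carbon should move the number further. The expectation for compound 3 is therefore a step in this assay of about a 1.3-fold lower number from compound 1 to compound 3 (0.11 log units; within the scatter), within the scatter, landing at an estimated 40000 nM with a range from 15000 nM to 110000 nM.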

Compound 3, half-maximal inhibitory concentration: 40100 nM
The estimate for compound 3 lay 1.0-fold (0.00 log units) below the measured number, within the range that was stated.
By their numbers in this assay, from the lowest: compounds 2, 3 and 1 (each within the scatter of the next, the first and the last beyond it).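

In this assay, chloro in place of methyl on this aromatic carbon gives a 1.3-fold lower number from compound 1 to compound 3 (0.11 log units; within the scatter), so compound 1 and compound 3 cannot be told apart at this position. Within the data shown here, this is the first view of that end of the molecule, and the exchange stays within the scatter, whereas the one earlier change, on the oxygen side, gave a 2.1-fold lower number from compound 1 to compound 2 (0.32 log units; beyond the scatter) and went beyond it. No outside information on these compounds bears on this result.

The compounds shown carry only methyl or chloro at this position, so it remains open whether an amine, a carboxylic acid or a methoxy group there would move the number. On these data alone, it also remains open whether the same exchange would stay within the scatter with the 4-fluorophenyl group of compound 2 on the oxygen side.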